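A few compounds are considered here, and "the series" means these few. Any claim that something is new, unique, unknown or untested is made for them only; others in the source may bear on it.

In a functional assay on A549 cells (Homo sapiens) for antiproliferative activity, read by MTT assay, with a stated time of 48 h (a lower number here means a stronger inhibitor, a higher number a weaker inhibitor), compound 1 (`COc1ccc(-c2nnc(NC(=O)/C=C/c3ccc(C)cc3)s2)cc1`) gives 0.58 ug/mL and compound 2 (`COc1ccc(-c2nnc(NC(=O)/C=C/c3ccc(F)cc3)s2)cc1`) gives 0.75 ug/mL. Compound 3 (`O=C(/C=C/c1ccc(F)cc1)Nc1nnc(-c2ccccc2)s1`) gives 1.82 ug/mL, so compound 2 stands close to compound 1 and apart from compound 3. Next is compound 4 (`COc1ccc(-c2nnc(NC(=O)/C=C/c3ccccc3)s2)cc1`), which differs from compound 2 as follows: hydrogen in place of fluoro on an aromatic carbon. Within the data shown here, only one measured step changes that same ring, a 1.3-fold higher number from compound 1 to compound 2 (0.11 log units; within the scatter). The other, a 2.4-fold higher number from compound 2 to compound 3 (0.39 log units; beyond the scatter), changes a different ring and bears on this change less directly. No step beyond the scatter is therefore expected, and the estimated step is a 1.2-fold higher number from compound 2 to compound 4 (0.08 log units; within the scatter). Compound 4 is estimated at 0.9 ug/mL, with an expected range of 0.4 ug/mL to 2 ug/mL.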

Compound 4, half-maximal inhibitory concentration: 0.68 ug/mL
Beside the measured number, compound 4's estimate is 1.3-fold (0.12 log units) above it; the range from low to high includes it.
By their numbers in this assay, from the lowest: compounds 1, 4 and 2 (each within the scatter of the next); then compound 3.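

At the position para to a large group, hydrogen reads level with fluoro (a 1.1-fold lower number from compound 2 to compound 4 (0.04 log units; within the scatter)) and with methyl (a 1.2-fold higher number from compound 1 to compound 4 (0.07 log units; within the scatter)) in this assay. With the unsubstituted ring now in the set, 4-fluorophenyl to phenyl shows that neither substituent is needed for a number in this range while the methoxy on the other ring stays in place. Nothing on hand explains this flat reading. Open, as far as these compounds go, is whether an amine, a carboxylic acid or a longer chain at this position would move the number beyond the scatter. Also open, from the compounds shown here alone, is whether hydrogen and fluoro stay level once the methoxy is gone.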